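Swapping the Dichlorophenyl Arm for a Biphenyl

The source may report more compounds than this note shows. Statements on the series, on what has been measured and on what is new or still open speak of the compounds shown alone.

Measured compounds:
Compound 1 `COc1ccc(/C=C/c2cc(OC)cc(OC)c2/C=C/C(=O)c2ccc(Cl)c(Cl)c2)cc1`: 7.5 ug/mL
Compound 2 `CCCCCCOc1ccc(C(=O)/C=C/c2c(/C=C/c3ccc(OC)cc3)cc(OC)cc2OC)cc1`: 10.4 ug/mL
Compound 3 `COc1ccc(/C=C/c2cc(OC)cc(OC)c2/C=C/C(=O)c2ccc(N)cc2)cc1`: 2.8 ug/mL

All three share a core and differ only in the ring attached to the carbonyl carbon. In a functional assay on B16-F10 cells (Mus musculus) for antiproliferative activity, read by MTT assay, with a stated time of 48 h (a lower number here means a stronger inhibitor, a higher number a weaker inhibitor), compound 1 gives 7.5 ug/mL, the second highest of the three numbers; compound 2 sits close to it, within the scatter, while compound 3 lies clearly lower. The step of a 2.7-fold lower number from compound 1 to compound 3 (0.43 log units; beyond the scatter) and the step of a 3.7-fold lower number from compound 2 to compound 3 (0.57 log units; beyond the scatter) are both modest and both point the same way, toward the amino-bearing ring.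

Compound 4 `COc1ccc(/C=C/c2cc(OC)cc(OC)c2/C=C/C(=O)c2ccc(-c3ccccc3)cc2)cc1` has not yet been measured. Compared with compound 1 the change is: 4-phenylphenyl in place of 3,4-dichlorophenyl on a carbonyl carbon. Neither measured step covers this change, since both of them lead to the amino group, which compound 4 does not carry. Going by the values given here, with no step to lean on, the expectation is a number near compound 1, with a 1.2-fold higher number from compound 1 to compound 4 (0.08 log units; within the scatter) expected to fall within the scatter. Compound 4 is therefore estimated at 9 ug/mL in this assay, with a range from 4 ug/mL to 22 ug/mL.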

Compound 4, half-maximal inhibitory concentration: 10.6 ug/mL
Estimate against measurement, compound 4: 1.2-fold (0.07 log units) below, within the range that was stated.
By their numbers in this assay, from the lowest: compound 3; then compounds 1, 2 and 4 (each within the scatter of the next).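

In this assay, the ring on the carbonyl carbon can carry a second aromatic ring without leaving the range of the non-amino compounds: 4-phenylphenyl in place of 3,4-dichlorophenyl gives a 1.4-fold higher number from compound 1 to compound 4 (0.15 log units; within the scatter), and phenyl in place of hexyloxy gives a 1.0-fold higher number from compound 2 to compound 4 (0.01 log units; within the scatter). The amino group still stands apart, with a 3.8-fold higher number from compound 3 to compound 4 (0.58 log units; beyond the scatter), so among these four compounds only compound 3 separates from the rest, while three quite different ring substituents give numbers within the scatter of one another. Nothing measured here explains why these numbers fall as they do.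

Still open, on these data alone, is whether the lower number of compound 3 needs a free amino group or would persist with a hydroxyl group or a dimethylamino group. An acetamide at the same place would test this further.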